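Imine side-chain variation on the quinolinone-free core series

This account rests on a few compounds, and the source may have more. Where it says the series, first, only, none or still open, it means among the compounds named here.

Measured so far in a functional assay, read by spectrophotometry, with a stated time of 3 min; a higher number here means a weaker inhibitor, a lower number a stronger inhibitor:
- compound 1, `Cc1ccc2[nH]c(=O)c(/C=N/N)cc2c1`: 11300 nM
- compound 2, `CCCC/N=C/c1cc2ccccc2[nH]c1=O`: 1810000 nM
- compound 3, `CCCC/N=C/c1cc2cc(C)ccc2[nH]c1=O`: 43300 nM

Compound 3 carries the butyl chain on the double-bonded nitrogen together with the methyl on the aromatic carbon. Within the data shown here, on the numbers so far it sits second highest of the three: compound 1 lies nearest, with a 3.8-fold higher number from compound 1 to compound 3 (0.58 log units; beyond the scatter) separating them, and compound 2 lies furthest, with a 42-fold lower number from compound 2 to compound 3 (1.62 log units; beyond the scatter) separating them.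

Compound 4, `Cc1ccc2[nH]c(=O)c(/C=N/CCO)cc2c1`, differs from compound 3 by hydroxy in place of ethyl on a saturated chain carbon, two bonds along the chain from a double-bonded nitrogen. Among the measured compounds shown here, no measured pair changes this position in the same way. For the measured compounds named here, the only step that touches the group on the double-bonded nitrogen is a 3.8-fold higher number from compound 1 to compound 3 (0.58 log units; beyond the scatter), where a chain without a donor or acceptor replaced a group carrying them and the number rose. The change to compound 4 puts a donor and an acceptor back at the end of the chain, so a movement in the opposite direction, toward the number of compound 1, is expected, but of uncertain size.

Compound 4 is therefore expected to give a modestly lower number, a 2.2-fold lower number from compound 3 to compound 4 (0.34 log units; beyond the scatter), with an estimate of 20000 nM and a range from 5000 nM to 80000 nM.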

Compound 4, half-maximal inhibitory concentration: 1190000 nM
For compound 4 the middle estimate is 60-fold (1.77 log units) below the measured one, outside the stated range (above it).
By their numbers in this assay, from the lowest: compound 1; then compound 3; then compounds 4 and 2 (each within the scatter of the next).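

In this assay, the step of a 27-fold higher number from compound 3 to compound 4 (1.44 log units; beyond the scatter) shows that this chain position is highly sensitive: hydroxy in place of ethyl, two bonds along the chain from the double-bonded nitrogen, takes the number up, not down. With the methylated core held constant, the step of a 110-fold higher number from compound 1 to compound 4 (2.02 log units; beyond the scatter) is also larger than a 3.8-fold higher number from compound 1 to compound 3 (0.58 log units; beyond the scatter), so among these three compounds the butyl chain lies closer to the amino group of compound 1 than the 2-hydroxyethyl chain does, and a hydroxy at the chain end does not reproduce the number of compound 1. No supporting measurement bears on the reason for this rise.

Open, on these data alone, is whether the rise belongs to the hydroxy itself or would also appear with a methoxy, an amine or a carboxylic acid at the chain end, and how a longer chain carrying the hydroxy would compare. Also open, as far as these compounds go, is whether the same change on the core of compound 2, which lacks the methyl, would give a step of similar size.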